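This account rests on a few compounds, and the source may have more. Where it says the series, first, only, none or still open, it means among the compounds named here.

Compound 1 `Cc1ccc2c(NCc3ccc(NC(=O)C4CCN(Cc5ncc[nH]5)CC4)cc3)nc(N(C)C)nc2c1` gives only a limit of > 20000 nM in a functional assay on SV5A8 cells (Homo sapiens) for cytotoxicity; on this read-out lower numbers stand for stronger inhibition and higher numbers for weaker inhibition.
Compound 2 `Cc1ccc2c(NCc3ccc(NC(=O)C4CCN(Cc5ccccc5)CC4)cc3)nc(N(C)CCN(C)C)nc2c1` gives only a limit of > 8830 nM in this assay.
Compound 3 `Cc1ccc2c(NCc3ccc(NC(=O)C4CCN(Cc5ccccc5)CC4)cc3)nc(N3CCNC(CCO)C3)nc2c1` gives only a limit of > 8420 nM in this assay.

Compound 1 therefore stands at a limit rather than a number, the highest of the three limits shown (the limit of > 20000 nM in this assay, at which 1 of the 3 values shown sits). Compound 4 `Cc1ccc2c(NCc3ccc(NC(=O)C4CCN(Cc5cccc(F)c5)CC4)cc3)nc(N(C)C)nc2c1` differs from compound 1 by 3-fluorophenyl in place of 1H-imidazol-2-yl on a saturated chain carbon bound to an amine nitrogen in a ring. Among the compounds with values here, the only recorded step, a step that the two limits leave unreadable from compound 2 to compound 3, changes another part of the shared core, and its two limits leave its size unreadable, so no measured step bears on this change. Nothing in the data points to a step beyond the scatter in this assay, and the step is estimated as a step that the limit leaves unreadable from compound 1 to compound 4. Compound 4 is accordingly expected at 25000 nM, with a range from 10000 nM to 60000 nM, most likely again reported only as a limit.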

Compound 4, half-maximal inhibitory concentration: > 4170 nM
Compound 4: no number, only a limit (the forecaster's own chance of this, stated with the estimate: 80%); the middle value is on the limit's open side.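

Compound 1 and compound 4 both give only limits in this assay, so the step between them cannot be read. The compounds shown leave open how the 3-fluorophenyl and 1H-imidazol-2-yl groups compare on this read-out.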